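Glycine-linked amide series: the benzyl(methyl)amide step

The source may report more compounds than this note shows. Statements on the series, on what has been measured and on what is new or still open speak of the compounds shown alone.

Measured so far in an assay on isolated protein for inhibition of thyroid hormone receptor alpha (Homo sapiens), read by fluorescence polarization; a higher number here means a weaker inhibitor, a lower number a stronger inhibitor:
compound 1 `CS(=O)(=O)c1ccc(C(=O)N2CCC(C(=O)N(Cc3ccccc3)c3ccccc3)CC2)cc1[N+](=O)[O-]`: > 60000 nM
compound 2 `CS(=O)(=O)c1ccc(C(=O)NCCC(=O)N2CCCCC2)cc1[N+](=O)[O-]`: > 60000 nM
compound 3 `CS(=O)(=O)c1ccc(C(=O)NCC(=O)N2CCCCC2)cc1[N+](=O)[O-]`: 44000 nM

The value for compound 1 is a limit of this assay, not a number. The value for compound 2 is likewise a limit. Going by the values given here, compound 3 gives the only numerical reading, and even that sits close to the limit, as the limit of > 60000 nM in this assay, at which 2 of the 3 values shown sit, shows.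

Compound 4 `CN(Cc1ccccc1)C(=O)CNC(=O)c1ccc(S(C)(=O)=O)c([N+](=O)[O-])c1` carries the change (benzyl(methyl)amino in place of piperidin-1-yl on a carbonyl carbon). Among the compounds with values here, no measured step is available for this kind of change. The expectation is a step of a 1.3-fold higher number from compound 3 to compound 4 (0.10 log units; within the scatter) from compound 3 to compound 4, no larger than the scatter and tending toward weaker binding. Compound 4 is therefore expected at 55000 nM in this assay, with a range of 20000 nM to 150000 nM, and a fair chance that only a limit is returned.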

Compound 4, half-maximal inhibitory concentration: > 60000 nM
Compound 4 ended at the assay's limit (the forecaster's own chance of this, stated with the estimate: 45%); middle value at least 1.0-fold (0.03 log units) away from the limit.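

In this assay, the reading for compound 4 is a limit and not a number. Benzyl(methyl)amino in place of piperidin-1-yl on a carbonyl carbon therefore gives only a floor, an at least 1.3-fold higher number from compound 3 to compound 4 (0.13 log units; that floor lies within the scatter), and this first step at the position shows no stronger binding, while its true size stays unread. Compound 3 remains the only numerical reading in the series, which otherwise sits at the ceiling: the limit of > 60000 nM in this assay, at which 3 of the 4 values shown sit.

From the compounds shown here alone, whether dimethylamino or morpholin-4-yl on this carbonyl carbon would return a number remains open. The order of compound 1, compound 2 and compound 4 also cannot be read.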